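Chalcone series: removing the para halogen

The source may hold more compounds than are shown below. What is called first, only, known or untested is meant among the compounds shown, and "the series" means these compounds.

Three chalcones have values in a functional assay on HCT-116 cells (Homo sapiens) for cytotoxicity, with a stated time of 48 h; on this read-out lower numbers stand for stronger inhibition and higher numbers for weaker inhibition. Compound 1 `COc1cc(OC)c(C(=O)/C=C/c2ccc(Cl)cc2)c(OC)c1` gives 5400 nM; compound 2 `COc1cc(OC)c(C(=O)/C=C/c2ccc(Br)cc2)c(OC)c1` gives 6200 nM; compound 3 `COc1cccc(/C=C/C(=O)c2c(O)cc(OC)cc2OC)c1` gives 7700 nM. Compound 2 stands second highest of the three numbers, with compound 1 nearest and compound 3 furthest, and both of these gaps lie within the scatter. Among the measured compounds shown here, the single one-place step measured so far, bromo in place of chloro on an aromatic carbon, gave a 1.1-fold higher number from compound 1 to compound 2 (0.06 log units; within the scatter); compound 3 differs from compound 2 in more than one place, so its value can only be set beside that of compound 2.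

Compound 4 `COc1cc(OC)c(C(=O)/C=C/c2ccccc2)c(OC)c1` is not yet measured. It differs from compound 2 as follows: hydrogen in place of bromo on an aromatic carbon. For the measured compounds named here, no measured step here removes a halogen from that ring; the only halogen step, between compound 1 and compound 2, was within the scatter. A step in this assay from compound 2 to compound 4 is therefore expected to be small, most likely toward a slightly higher number, a 1.3-fold higher number from compound 2 to compound 4 (0.11 log units; within the scatter). Compound 4 is estimated at 8000 nM, within 3500 nM to 18000 nM.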

Compound 4, half-maximal inhibitory concentration: 6900 nM
Estimate against measurement, compound 4: 1.2-fold (0.06 log units) above; the range from low to high includes it.
By their numbers in this assay, from the lowest: compounds 1, 2, 4 and 3 (each within the scatter of the next).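

In this assay, hydrogen in place of bromo on an aromatic carbon gives a 1.1-fold higher number from compound 2 to compound 4 (0.05 log units; within the scatter), and hydrogen in place of chloro at this same position gives a 1.3-fold higher number from compound 1 to compound 4 (0.11 log units; within the scatter). Both steps lie within the scatter, so bromo, chloro and hydrogen cannot be told apart at this position, and a halogen there is not shown to be needed for the value on this shared core. No measured evidence bears on this result.

Still open, from the compounds shown here alone, is whether a group of a different kind at this position, such as an amine or a carboxylic acid, would give a step beyond the scatter. The same question stands for a longer chain there, such as a butyl group.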